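This account rests on a few compounds, and the source may have more. Where it says the series, first, only, none or still open, it means among the compounds named here.

Measured in a functional assay on MCF7 cells (Homo sapiens) for inhibition, read by MTT assay, with a stated time of 24 h; a higher number here means a weaker inhibitor of growth, a lower number a stronger inhibitor of growth:
- compound 1 `Cn1cc(-c2nc3ccccc3n2C(=O)c2ccccc2)c2ccccc21`: 43700 nM
- compound 2 `COc1cccc(C(=O)n2c(-c3cn(C)c4ccccc34)nc3ccccc32)c1`: 15700 nM
- compound 3 `COc1cc(C(=O)n2c(-c3cn(C)c4ccccc34)nc3ccccc32)cc(OC)c1OC`: 5400 nM

Compound 2 stands in the middle of these three, with compound 1 higher and compound 3 lower. Compound 4 `Cn1cc(-c2nc3ccccc3n2C(=O)c2ccccc2Br)c2ccccc21` follows from compound 2 by one change: 2-bromophenyl in place of 3-methoxyphenyl on a carbonyl carbon. Within the data shown here, one measured step bears on this, the modest 2.8-fold lower number from compound 1 to compound 2 (0.44 log units; beyond the scatter), which came with methoxy in place of hydrogen on an aromatic carbon. Among the measured compounds shown here, compound 4 has no methoxy, and no measured compound shows what bromine does. A small step toward a higher number in this assay is therefore expected, possibly not clearing the scatter. The estimate is a 1.6-fold higher number from compound 2 to compound 4 (0.20 log units; within the scatter). Compound 4 is expected at 25000 nM, within an estimated range of 9000 nM to 60000 nM.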

Compound 4, concentration for 50% growth inhibition: 70100 nM
Estimate against measurement, compound 4: 2.8-fold (0.45 log units) below, outside the stated range (above it).
By their numbers in this assay, from the lowest: compound 3; then compound 2; then compounds 1 and 4 (each within the scatter of the next).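

In this assay, 2-bromophenyl in place of 3-methoxyphenyl on the carbonyl carbon gives a 4.5-fold higher number from compound 2 to compound 4 (0.65 log units; beyond the scatter) and so moves the number the opposite way from the methoxy step. Bromo in place of hydrogen on an aromatic carbon gives a 1.6-fold higher number from compound 1 to compound 4 (0.21 log units; within the scatter) and so does not set compound 4 apart from compound 1. On these compounds, bromine at this place does not carry over the gain seen with methoxy.

As far as these compounds go, whether an amine or a carboxylic acid on this phenyl would change the number remains open. No evidence is available on what lies behind these steps.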